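Methoxy on the phenyl tail: compound 2 to compound 3

This account rests on a few compounds, and the source may have more. Where it says the series, first, only, none or still open, it means among the compounds named here.

Among the compounds with values here, in an assay on CHO cells for displacement of a labelled ligand from adenosine receptor A2b (Homo sapiens), read by scintillation counting, with a stated time of 75 min (on this read-out lower numbers stand for stronger inhibition and higher numbers for weaker inhibition), compound 2 `O=C(CCc1ccccc1)Nc1nc2ccccc2c(=O)s1` gives 365 nM, one of only two numbers known so far. Compound 1 `O=C(CCCc1ccccc1)Nc1nc2ccsc2c(=O)s1` gives 547 nM in this assay, and the two values lie within the scatter of each other, so neither is separated from the other. Compound 3 `COc1cccc(CCC(=O)Nc2nc3ccccc3c(=O)s2)c1` carries methoxy in place of hydrogen on an aromatic carbon, meta to a large group. Within the data shown here, no measured pair shows this change, so no step size can be read from the series. The expected step of a 1.2-fold lower number from compound 2 to compound 3 (0.09 log units; within the scatter) is small, inside the scatter. Compound 3 is expected to give 300 nM in this assay, within a range of 110 nM to 900 nM.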

Compound 3, inhibition constant: 225 nM
Estimate against measurement, compound 3: 1.3-fold (0.12 log units) above; the measured number falls inside the stated range.
By their numbers in this assay, from the lowest: compounds 3, 2 and 1 (each within the scatter of the next, the first and the last beyond it).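

In this assay, within the data shown here, phenyl to 3-methoxyphenyl is the first one-place step, and it reads a 1.6-fold lower number from compound 2 to compound 3 (0.21 log units; within the scatter) on the phenyl tail of compound 2. This aromatic carbon therefore takes a methoxy with no separation from the value of the hydrogen parent. No measurement bears on what lies behind this step.

Still open, from the compounds shown here alone, is whether ethoxy, an amine or a carboxylic acid on the same aromatic carbon would give a step beyond the scatter. Going by these compounds, the effect of methoxy elsewhere on this ring also remains open.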